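The source may report more compounds than this note shows. Statements on the series, on what has been measured and on what is new or still open speak of the compounds shown alone.

Compound 3 `NC(=O)CCCSC[C@H](NC(=O)OCc1ccccc1)C(=O)Nc1ccccc1` stands lowest of the three measured compounds in an assay for inhibition of NAD-dependent protein deacylase sirtuin-6 (Homo sapiens), read by HPLC, with stated times of 15 min and 1 h, tested at 333 uM (on this read-out lower numbers stand for less inhibition and higher numbers for more inhibition at the one concentration tested (going by the name of the read-out)), where compound 3 gives 11%. Compound 1 `O=C(CCCSC[C@H](NC(=O)OCc1ccccc1)C(=O)Nc1ccccc1)NCc1ccccc1` gives 30% in this assay, and compound 2 `O=C(O)CCCNC(=O)CCCSC[C@H](NC(=O)OCc1ccccc1)C(=O)Nc1ccccc1` gives 35%. Compound 4 `O=C(O)CCNC(=O)CCCSC[C@H](NC(=O)OCc1ccccc1)C(=O)Nc1ccccc1` differs from compound 3 by 2-carboxyethyl in place of hydrogen on an amide-type nitrogen. Going by the values given here, two measured steps bear on this change: a number 24 percentage points lower from compound 2 to compound 3 (beyond the scatter) and a number 19 percentage points lower from compound 1 to compound 3 (beyond the scatter), each the removal of a group from that amide-type nitrogen. Putting a 2-carboxyethyl group back, a near neighbour of 3-carboxypropyl, is therefore expected to undo most of the first of those losses, a modest rise of a number 22 percentage points higher from compound 3 to compound 4 (beyond the scatter) in this assay. Compound 4 is thus estimated at 33%, with a likely range from 20% to 46%.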

Compound 4, a percentage reported as inhibition, at one concentration (the size of the read-out at that concentration, not a potency): 43%
Beside the measured number, compound 4's estimate is 10 percentage points below it; low and high end bracket the measured number.
By their numbers in this assay, from the lowest: compound 3; then compounds 1, 2 and 4 (each within the scatter of the next, the first and the last beyond it).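

In this assay, 2-carboxyethyl on the amide-type nitrogen gives a number 32 percentage points higher from compound 3 to compound 4 (beyond the scatter), so this position responds strongly to this group. Against the benzyl group, the new chain gives a number 13 percentage points higher from compound 1 to compound 4 (beyond the scatter), a gap that 3-carboxypropyl did not open. Shortening the chain gives a number 8 percentage points higher from compound 2 to compound 4 (within the scatter), which lies within the scatter, so these two carboxy chains cannot be told apart here.

Nothing measured explains these steps. On these data alone, whether a carboxymethyl group, or the same chain ending in an amine or a methyl ester, would hold this level stays open.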